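The source may report more compounds than this note shows. Statements on the series, on what has been measured and on what is new or still open speak of the compounds shown alone.

Working notes on the series. Within the data shown here, compound 2 `CCC(CC)c1ccc2c(NCCCNCc3ccco3)ccnc2c1` sits at the bottom of the two numbers measured so far: in an ADME assay for permeability, using PAMPA, with a stated time of 30 min, at pH 7.4 (on this read-out higher numbers stand for higher permeability and lower numbers for lower permeability), compound 2 gives 23 10^-6 cm/s, whereas compound 1 `c1ccc(Oc2ccc3c(NCCCNCc4ccco4)ccnc3c2)cc1` gives 317 10^-6 cm/s in this assay. Among the measured compounds shown here, the one measured step, a 14-fold lower number from compound 1 to compound 2 (1.14 log units; beyond the scatter), arises from pentan-3-yl in place of phenoxy on an aromatic carbon.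

Compound 3 `COc1ccc(-c2ccc3c(NCCCNCc4ccco4)ccnc3c2)cc1` is the next member to be measured in this assay. It differs from compound 2 by 4-methoxyphenyl in place of pentan-3-yl on an aromatic carbon. For the measured compounds named here, the only step on record that bears on this change is the one from compound 1 to compound 2, and it runs in the opposite sense: an aromatic substituent was exchanged for pentan-3-yl and the number fell by a large margin. Returning to an aromatic substituent at the same carbon, now a 4-methoxyphenyl, is therefore expected to move the number back upward, though the new group is not the phenoxy of compound 1 and the size of the recovery is uncertain. For compound 3 the expected step in this assay is a 5.7-fold higher number from compound 2 to compound 3 (0.75 log units; beyond the scatter). The estimate for compound 3 in this assay is 130 10^-6 cm/s, within a range from 35 10^-6 cm/s to 400 10^-6 cm/s.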

Compound 3, apparent permeability: 237 10^-6 cm/s
Compound 3: middle estimate off by 1.8-fold (0.26 log units), on the low side, within the range that was stated.
By their numbers in this assay, from the lowest: compound 2; then compounds 3 and 1 (each within the scatter of the next).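

At this aromatic carbon the read-out in this assay now has three groups to compare, and 4-methoxyphenyl in place of pentan-3-yl gives a 10-fold higher number from compound 2 to compound 3 (1.01 log units; beyond the scatter) as a large step, so the earlier fall is not specific to phenoxy as the group that leaves. Among these compounds, exchanging phenoxy for 4-methoxyphenyl gives a 1.3-fold lower number from compound 1 to compound 3 (0.13 log units; within the scatter) and stays within the scatter, so the directly attached ring with its methoxy group and the oxygen-linked phenyl ring cannot be told apart here, while pentan-3-yl stands apart from both, with no compound of the three going against this. Nothing at hand gives a cause for either step.

As far as these compounds go, it remains open whether an aromatic ring is what separates these groups, since a saturated ring such as cyclohexyl at this carbon could fall with either side, and a plain phenyl would show whether the methoxy group matters at all. From the compounds shown here alone, it is equally open how this carbon tolerates a group of another kind, such as an amine or a carboxylic acid, or a longer chain.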